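This account rests on a few compounds, and the source may have more. Where it says the series, first, only, none or still open, it means among the compounds named here.

Measured compounds:
- compound 1, `CCCCNc1nc(N)nc(C)c1CCCn1c(C)nc2ccccc21`: 366 nM
- compound 2, `CCCCNc1nc(N)nc(C)c1CCCC(C)(C)O`: 1220 nM
- compound 3, `CCCCNc1nc(N)nc(C)c1CCCn1ccc2ccccc21`: 1100 nM

These three compounds share a core and differ only in the group carried at the end of the saturated chain. In an assay on HEK293 cells for agonist activity at Toll-like receptor 8 (Homo sapiens), read by spectrophotometry (on this read-out lower numbers stand for an effect already at smaller amounts and higher numbers for an effect only at larger amounts of compound), compound 2 gives 1220 nM, the highest of the three numbers. Compound 3 gives 1100 nM, which sits within the usual scatter of the number for compound 2, so no order between the two can be read. Compound 1 gives 366 nM, a number lower than that of compound 2 by more than the scatter.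

The next compound, compound 4, `CCCCNc1nc(N)nc(C)c1CCCn1cccn1`, has not yet been measured in this assay. It differs from compound 2 in one place: 1H-pyrazol-1-yl in place of 1-hydroxy-1-methylethyl on a saturated chain carbon, three bonds along the chain from an aromatic carbon

Among the compounds with values here, no measured pair shows this exact change, so the expectation rests on the spread of the three numbers alone. The step of a 1.5-fold lower number from compound 2 to compound 4 (0.18 log units; within the scatter) is expected to be small, toward a lower number, and possibly not beyond the scatter. Compound 4 is therefore estimated at 800 nM, with a range from 300 nM to 2500 nM.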

Compound 4, half-maximal effective concentration: 1050 nM
The estimate for compound 4 lay 1.3-fold (0.12 log units) below the measured number, and the stated range covers the measured number.
By their numbers in this assay, from the lowest: compound 1; then compounds 4, 3 and 2 (each within the scatter of the next).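

In this assay, replacing 1-hydroxy-1-methylethyl with 1H-pyrazol-1-yl on a saturated chain carbon, three bonds along the chain from an aromatic carbon, gives a 1.2-fold lower number from compound 2 to compound 4 (0.07 log units; within the scatter). At this position, then, an open-chain alcohol with a hydrogen-bond donor and a five-membered aromatic ring with none cannot be told apart by their numbers. Compound 1, at 366 nM, still has a lower number than compound 4, so the presence of a ring at the chain end does not alone give a number like that of compound 1, and no measurement offered here explains this result.

From the compounds shown here alone, it remains open whether a primary amine or a carboxylic acid at the chain end would also leave the number within the scatter of compound 2. A longer chain carrying the same 1H-pyrazol-1-yl group is equally unresolved.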